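The compounds below may be only part of what the source reports. "The series", "measured", "known", "first", "only" and "open" are said of these compounds alone.

In a functional assay on MCF7 cells (Homo sapiens) for cytotoxicity, read by MTT assay, with a stated time of 48 h (on this read-out higher numbers stand for weaker inhibition and lower numbers for stronger inhibition), compound 1 `O=C(/C=C/c1ccccc1F)Nc1ccc(CC2=CC(=O)OC2)cc1` gives only a limit, > 50000 nM. Among the measured compounds shown here, compound 2 `C=C1OC(=O)C=C1Cc1ccc(NC(=O)/C=C/c2cccc(F)c2)cc1` reads 39000 nM, the only true number so far, so no measured step yet shows how far a value can move. Compound 3 `C=C1OC(=O)C=C1Cc1ccc(NC(=O)/C=C/c2ccccc2F)cc1` has the same atoms as compound 2, joined differently: 2-fluorophenyl in place of 3-fluorophenyl on a double-bonded chain carbon bound to a double-bonded chain carbon. For the measured compounds named here, with no measured step as a guide, no shift beyond the usual scatter in this assay is expected, and the estimated change a 1.1-fold lower number from compound 2 to compound 3 (0.03 log units; within the scatter) is small, with no clear direction. For compound 3 the expected value is 36000 nM, within a range of 16000 nM to 80000 nM.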

Compound 3, half-maximal inhibitory concentration: 13800 nM
The estimate for compound 3 lay 2.6-fold (0.42 log units) above the measured number, outside the stated range (below it).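

In this assay, 2-fluorophenyl in place of 3-fluorophenyl gives a 2.8-fold lower number from compound 2 to compound 3 (0.45 log units; beyond the scatter), so this place on the chain responds to where the fluorine sits, even though the atoms stay the same. Compound 1 gives only a limit of the assay: the limit of > 50000 nM in this assay, at which 1 of the 3 values shown sits. The change in the group on the saturated chain carbon, with 2-fluorophenyl kept, gives an at least 3.6-fold lower number from compound 1 to compound 3 (0.55 log units; beyond the scatter), a step whose true size is only bounded.

From the compounds shown here alone, whether 4-fluorophenyl or plain phenyl would read lower or higher stays open. So does whether a chlorine or a methoxy group in the fluorine's place would follow the same trend.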